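A few compounds are considered here, and "the series" means these few. Any claim that something is new, unique, unknown or untested is made for them only; others in the source may bear on it.

Measured in a functional assay on A549 cells (Homo sapiens) for cytotoxicity, read by MTT assay, with a stated time of 72 h; a lower number here means a stronger inhibitor, a higher number a weaker inhibitor:
- compound 1 `O=C1c2c[n+]([O-])c3ccccc3c2C(=O)c2c1c1ccccc1n2Cc1cn(C[C@H](O)CO)nn1`: 1030 nM
- compound 2 `CC1(C)OCC(Cn2cc(Cn3c4c(c5ccccc53)C(=O)c3c[n+]([O-])c5ccccc5c3C4=O)nn2)O1`: 80 nM
- compound 3 `CC1(C)OC[C@@H](Cn2cc(Cn3c4c(c5ccccc53)C(=O)c3c[n+]([O-])c5ccccc5c3C4=O)nn2)O1`: 4700 nM

Compound 1 sits in the middle of these three numbers. Next comes compound 4 `CCCN1CCN(CCCCn2c3c(c4ccccc42)C(=O)c2c[n+]([O-])c4ccccc4c2C3=O)CC1`, in which 3-(4-propylpiperazin-1-yl)propyl replaces 1-(2,3-dihydroxypropyl)-1H-1,2,3-triazol-4-yl on a saturated chain carbon bound to an aromatic nitrogen: 3-(4-propylpiperazin-1-yl)propyl in place of 1-(2,3-dihydroxypropyl)-1H-1,2,3-triazol-4-yl on a saturated chain carbon bound to an aromatic nitrogen.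

The nearest evidence comes from changes at the far end of the same side chain. These pull in opposite directions: a 13-fold lower number from compound 1 to compound 2 (1.11 log units; beyond the scatter) is large, while a 4.6-fold higher number from compound 1 to compound 3 (0.66 log units; beyond the scatter) is modest. The widest gap, a 59-fold higher number from compound 2 to compound 3 (1.77 log units; beyond the scatter), goes with the fact that one of compounds 2 and 3 is drawn with a defined configuration and the other without, at the place where they differ. None of these steps removes the triazole, so the direction remains uncertain, though a modest fall is expected. The estimated change is a 2.6-fold lower number from compound 1 to compound 4 (0.41 log units; beyond the scatter). For compound 4, the expected value is 400 nM, with an estimated range of 70 nM to 2500 nM.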

Compound 4, half-maximal inhibitory concentration: 320 nM
The estimate for compound 4 lay 1.3-fold (0.10 log units) above the measured number; measured number inside the range.
By their numbers in this assay, from the lowest: compound 2; then compound 4; then compound 1; then compound 3.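

Replacing 1-(2,3-dihydroxypropyl)-1H-1,2,3-triazol-4-yl with 3-(4-propylpiperazin-1-yl)propyl gives a 3.2-fold lower number from compound 1 to compound 4 (0.51 log units; beyond the scatter) in this assay. Compounds 2 and 3 keep the triazole, whereas compound 4 shows that this place tolerates a group without the triazole, its hydrogen-bond donors or a defined stereocentre. Nothing available bears on why the number falls.

Because the triazole, diol and piperazine change together, the step cannot assign the fall to any one of them. A morpholine in place of the 4-propylpiperazine, or a shorter chain to the piperazine, would help separate these parts.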